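Methoxy for Bromo on a Weak Cell Inhibitor

A few compounds are considered here, and "the series" means these few. Any claim that something is new, unique, unknown or untested is made for them only; others in the source may bear on it.

Compound 2 `O=C1/C(=C/c2ccccc2Br)CCCc2ccccc21` was tested in a functional assay on Molt4/C8 cells (Homo sapiens) for inhibition (a lower number here means a stronger inhibitor, a higher number a weaker inhibitor), where compound 2 gives 38400 nM. A related compound, compound 1 `O=C1/C(=C/c2ccccc2F)Cc2ccccc21`, gives 54200 nM in this assay; the two numbers lie within the usual scatter of each other, so the data do not separate them. Compound 3 `COc1ccccc1/C=C1\CCCc2ccccc2C1=O` has not yet been measured. It differs from compound 2 in a single place: methoxy in place of bromo on an aromatic carbon. Among the compounds with values here, no measured pair shows what this exchange does here, so nothing in the data points to a step in either direction beyond the scatter. Compound 3 is therefore expected to land close to where compound 2 stands. The step of a 1.0-fold higher number from compound 2 to compound 3 (0.02 log units; within the scatter) is expected to stay small. The estimate for compound 3 in this assay is 40000 nM, within a range from 15000 nM to 120000 nM.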

Compound 3, half-maximal inhibitory concentration: 37100 nM
Beside the measured number, compound 3's estimate is 1.1-fold (0.03 log units) above it; the measured number falls inside the stated range.
By their numbers in this assay, from the lowest: compounds 3, 2 and 1 (each within the scatter of the next).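

In this assay, methoxy in place of bromo on an aromatic carbon ortho to a large group gives a 1.0-fold lower number from compound 2 to compound 3 (0.01 log units; within the scatter) and so stays within the scatter. Within the data shown here, this is the first measured exchange at this position, and it shows that the assay does not separate these two groups, even though methoxy has 2 heavy atoms and 1 hydrogen-bond acceptor while bromo has 1 heavy atom and 0 hydrogen-bond acceptors. No measurement here offers an explanation for this result.

On these data alone, it remains open whether an amine, a carboxylic acid or a longer chain such as ethoxy at this position would move the number beyond the scatter. The compounds shown also do not reveal whether the same exchange would behave alike on the core of compound 1.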